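This account rests on a few compounds, and the source may have more. Where it says the series, first, only, none or still open, it means among the compounds named here.

Measured so far in a functional assay on DLD-1 cells (Homo sapiens) for antiproliferative activity, read by trypan blue exclusion; on this read-out lower numbers stand for stronger inhibition and higher numbers for weaker inhibition:
compound 1 `COc1cc(OC)c(/C=C/S(=O)(=O)Cc2ccc(OC)c(OP(=O)(O)O)c2)c(OC)c1` gives 7 nM
compound 2 `COc1cc(OC)c(/C=C/S(=O)(=O)Cc2ccc(Cl)cc2)c(OC)c1` gives 15000 nM
compound 3 `COc1cc(OC)c(/C=C/S(=O)(=O)Cc2ccc([N+](=O)[O-])cc2)c(OC)c1` gives 15000 nM

Compound 3 stands level with compound 2 at the digits shown, and the two together hold the highest numbers of the three. Among the compounds with values here, compound 1 is the furthest away: its number lies far below that of compound 3, a gap well beyond the scatter, though no single-point step connects the two. Within the data shown here, the one step between compounds that differ in one place is no change at the digits printed from compound 2 to compound 3 (within the scatter), which is flat within the scatter.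

Compound 4 `COc1cc(OC)c(/C=C/S(=O)(=O)Cc2ccc(C#N)cc2)c(OC)c1` differs from compound 3 thus: cyano in place of nitro on an aromatic carbon. Among the measured compounds shown here, the only measured step that bears on this change is no change at the digits printed from compound 2 to compound 3 (within the scatter), a swap of groups on the same aromatic carbon that moved nothing in this assay. For compound 4 the step of no change at the digits printed from compound 3 to compound 4 (within the scatter) is therefore expected to stay within the scatter, in no particular direction. Compound 4 is estimated at 15000 nM, with a range from 6000 nM to 35000 nM.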

Compound 4, half-maximal inhibitory concentration: 20000 nM
Beside the measured number, compound 4's estimate is 1.3-fold (0.12 log units) below it; the measured number falls inside the stated range.
By their numbers in this assay, from the lowest: compound 1; then compounds 2, 3 and 4 (each within the scatter of the next).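

In this assay, cyano in place of nitro gives a 1.3-fold higher number from compound 3 to compound 4 (0.12 log units; within the scatter) and cyano in place of chloro gives a 1.3-fold higher number from compound 2 to compound 4 (0.12 log units; within the scatter) at this aromatic carbon, para to a large group. Where one flat step stood before, chloro, nitro and cyano now form a set of three groups that this read-out cannot separate, so the flat result is not confined to a single pair. Exchanging a double bond outside the aromatic ring for a triple bond, with one heavy atom fewer, also leaves the number within the scatter, and nothing available explains this flat result.

Going by these compounds, whether an amine, a carboxylic acid or a hydroxyl group at this carbon would stay at the same level remains open. Compound 1 differs from compounds 2, 3 and 4 in more than one place, so its number cannot be tied to any single change.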